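Bromo for Trifluoromethyl on a Thiourea Sulfonamide

A few compounds are considered here, and "the series" means these few. Any claim that something is new, unique, unknown or untested is made for them only; others in the source may bear on it.

Of the compounds shown here, two have been measured so far in a functional assay on A-431 cells (Homo sapiens) for antiproliferative activity, read by MTT assay, with a stated time of 72 h; a lower number here means a stronger inhibitor, a higher number a weaker inhibitor. Compound 1 `C#Cc1cccc(Nc2ncnc3cc(OC)c(OCCCCC(=O)Nc4ccc(S(N)(=O)=O)cc4)cc23)c1` gives 17700 nM. Compound 2 `NS(=O)(=O)c1ccc(NC(=S)Nc2ccc3ncnc(Nc4cccc(C(F)(F)F)c4)c3c2)cc1` gives 21700 nM, a number so close to that of compound 1 that the two lie within the usual scatter of one another; neither can be called the stronger. The unmeasured compound 3 `NS(=O)(=O)c1ccc(NC(=S)Nc2ccc3ncnc(Nc4cccc(Br)c4)c3c2)cc1` keeps the thiourea, the sulfonamide and the shared core of compound 2 and differs only in one place: bromo in place of trifluoromethyl on an aromatic carbon. Within the data shown here, no measured pair shows what such a swap does here, so the expectation for compound 3 rests on compound 2 alone. The author expects the step of a 1.1-fold lower number from compound 2 to compound 3 (0.04 log units; within the scatter) to stay within the scatter, with no clear direction. Compound 3 is therefore estimated at 20000 nM, within a range from 7000 nM to 60000 nM.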

Compound 3, half-maximal inhibitory concentration: 20700 nM
Beside the measured number, compound 3's estimate is 1.0-fold (0.01 log units) below it, and the stated range covers the measured number.
By their numbers in this assay, from the lowest: compounds 1, 3 and 2 (each within the scatter of the next).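

In this assay, replacing 3-(trifluoromethyl)phenyl with 3-bromophenyl gives a 1.0-fold lower number from compound 2 to compound 3 (0.02 log units; within the scatter), the only single-place step shown in this series. On this aromatic carbon, meta to a large group, the number therefore does not separate bromo from trifluoromethyl, even though one heavy atom takes the place of four. Nothing shown here bears on why the two groups read alike.

The compounds shown leave open whether an amine or a carboxylic acid on the same carbon would give a number outside the scatter of compound 2 and compound 3. They also leave open whether a urea in place of the thiourea, with either of these two groups kept on the ring, would read any differently.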